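Trading Chloro for Methoxy on Compound 1

The source may hold more compounds than are shown below. What is called first, only, known or untested is meant among the compounds shown, and "the series" means these compounds.

In a functional assay on A549 cells (Homo sapiens) for antiproliferative activity, read by XTT assay, with a stated time of 24 h (a higher number here means a weaker inhibitor, a lower number a stronger inhibitor), compound 1 `Fc1ccc(C2CC(c3ccc(Cl)s3)=NN2c2nc(-c3ccc(Cl)cc3)cs2)cc1` gives 125 ug/mL, the highest of the two numbers shown. The nearest measured neighbour, compound 3 `Cc1ccc(C2=NN(c3nc(-c4ccc([N+](=O)[O-])cc4)cs3)C(c3ccc(F)cc3)C2)s1`, gives 16.7 ug/mL. Compound 2 `Cc1ccc(C2=NN(c3nc(-c4ccccc4)cs3)C(c3ccc(F)cc3)C2)s1` reports no number but a limit, > 500 ug/mL; this is the limit of > 500 ug/mL in this assay, at which 1 of the 3 values shown sits. Going by the values given here, the one measured step, an at least 29-fold lower number from compound 2 to compound 3 (1.47 log units; beyond the scatter), concerns a different change and so does not bear directly on the new compound. Compound 4 `COc1ccc(-c2csc(N3N=C(c4ccc(Cl)s4)CC3c3ccc(F)cc3)n2)cc1` differs from compound 1 by methoxy in place of chloro on an aromatic carbon. Among the compounds with values here, no measured step covers this swap, so no shift beyond the scatter is expected. The estimate for compound 4 is 120 ug/mL, with a range from 40 ug/mL to 400 ug/mL. The expected step is a 1.0-fold lower number from compound 1 to compound 4 (0.02 log units; within the scatter).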

Compound 4, half-maximal inhibitory concentration: > 500 ug/mL
Compound 4: only a limit was reported (the forecaster's own chance of this, stated with the estimate: 10%); middle value at least 4.1-fold (0.61 log units) away from the limit.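

In this assay, the group at this position on the core of compound 1 clearly matters: methoxy in place of chloro gives an at least 4.0-fold higher number from compound 1 to compound 4 (0.60 log units; beyond the scatter). Going by these compounds alone, until now, the only measured change at this position was nitro in place of hydrogen, on a different core. Compound 4 gives only a limit, > 500 ug/mL, so the true size of the step stays unknown, and this limit recurs: the limit of > 500 ug/mL in this assay, at which 2 of the 4 values shown sit.

Going by these compounds, it remains open how an amine or a nitrile at this position would read on the core of compound 1. On these data alone, whether nitro would give a lower number on that core is also open.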